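The source may hold more compounds than are shown below. What is called first, only, known or untested is meant among the compounds shown, and "the series" means these compounds.

Three compounds sharing one core were tested in a functional assay on SMMC-7721 cells (Homo sapiens) for cytotoxicity, read by MTT assay, with a stated time of 72 h; on this read-out higher numbers stand for weaker inhibition and lower numbers for stronger inhibition. Compound 1 `CCNC(=O)N1CCN(C(=S)SCc2cn(Cc3ccccc3F)nn2)CC1` gives > 128000 nM, which is a limit of the assay rather than a number. Compound 3 `CC(C)(C)NC(=O)N1CCN(C(=S)SCc2cn(Cc3ccccc3F)nn2)CC1` likewise gives > 128000 nM, again a limit. Among the compounds with values here, compound 2 `CC(C)NC(=O)N1CCN(C(=S)SCc2cn(Cc3ccccc3F)nn2)CC1` gives 7130 nM, the only number among the three, and it stands alone because of the limit of > 128000 nM in this assay, at which 2 of the 3 values shown sit. The step of an at least 17-fold lower number from compound 1 to compound 2 (1.25 log units; beyond the scatter) is large, and the step of an at least 17-fold higher number from compound 2 to compound 3 (1.25 log units; beyond the scatter) is equally large in the other direction; the step that the two limits leave unreadable from compound 1 to compound 3 cannot be read from two limits.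

Compound 4 `O=C(NCc1ccccc1)N1CCN(C(=S)SCc2cn(Cc3ccccc3F)nn2)CC1` has not yet been measured. It differs from compound 2 by benzyl in place of isopropyl on an amide-type nitrogen. Both measured steps bear on this change, since each alters the same group on the amide-type nitrogen. A step of the expected size, a 5.6-fold higher number from compound 2 to compound 4 (0.75 log units; beyond the scatter), toward weaker inhibition is estimated for compound 4 because the step of an at least 17-fold higher number from compound 2 to compound 3 (1.25 log units; beyond the scatter) shows that adding one methyl at this position already moved the value to the limit, and benzyl is a far greater alteration. Compound 4 is therefore expected at about 40000 nM, within a range from 5000 nM to 128000 nM, with a real chance that only a limit is recorded.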

Compound 4, half-maximal inhibitory concentration: > 128000 nM
Compound 4: no number, only a limit (the forecaster's own chance of this, stated with the estimate: 55%); middle value at least 3.2-fold (0.50 log units) away from the limit.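

The change from isopropyl to benzyl on the amide-type nitrogen gives an at least 17-fold higher number from compound 2 to compound 4 (1.25 log units; beyond the scatter). Loss of a measurable value at this nitrogen is therefore not confined to the saturated chains of compounds 1 and 3: a group carrying a six-membered aromatic ring also ends at a limit, and of the four groups shown only the isopropyl of compound 2 yields a number. The steps among compounds 1, 3 and 4 cannot be read, because all three rest on the same limit rather than on numbers: the limit of > 128000 nM in this assay, at which 3 of the 4 values shown sit.

From the compounds shown here alone, it remains open whether a group such as propyl or cyclopropyl on this nitrogen would also give a number. Going by these compounds, it is equally open whether phenyl, or a chain ending in an amine, would do so.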